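The source may hold more compounds than are shown below. What is called first, only, known or untested is meant among the compounds shown, and "the series" means these compounds.

Measured compounds:
compound 1 `CNC(=O)Cn1nc(N)c2c(C(F)(F)F)cc(-c3ccccc3)nc21`, 14400 nM;
compound 2 `CCCNC(=O)Cn1nc(N)c2c(C(F)(F)F)cc(-c3ccccc3)nc21`, 15500 nM;
compound 3 `Nc1nn(CC(=O)NC2CC2)c2nc(-c3ccccc3)cc(C(F)(F)F)c12`, "not active" (no number reported).

In a functional assay on DU-145 cells (Homo sapiens) for cytotoxicity, read by MTT assay, with a stated time of 24 h (a lower number here means a stronger inhibitor, a higher number a weaker inhibitor), compound 2 gives 15500 nM, the highest of the two numbers; its nearest neighbour is compound 1 with 14400 nM, and the two stand within the scatter of each other. Compound 3 is reported in this assay only as "not active" (no number reported), without a number.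

Compound 4 `Nc1nn(CC(=O)NCc2ccccc2)c2nc(-c3ccccc3)cc(C(F)(F)F)c12` is the unmeasured member. Compared with compound 2, the change is phenyl in place of ethyl on a saturated chain carbon bound to an amide-type nitrogen.

Among the compounds with values here, only one measured step touches the same place: a 1.1-fold higher number from compound 1 to compound 2 (0.03 log units; within the scatter). That step lies within the scatter, so it speaks against a large effect of a change at this position, but it is a small change and only one; compound 3, also altered at this place, gave no number at all, so the data leave open that a larger group here removes activity. On that basis compound 4 is expected to stay near compound 2 in this assay, with a step of a 1.0-fold higher number from compound 2 to compound 4 (0.01 log units; within the scatter), and the estimate carries a real chance of no number being reported.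

Compound 4 is therefore estimated at 16000 nM, within a range from 5000 nM to 60000 nM.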

Compound 4, half-maximal inhibitory concentration: 15600 nM
Estimate against measurement, compound 4: 1.0-fold (0.01 log units) above; the range from low to high includes it.
By their numbers in this assay, from the lowest: compounds 1, 2 and 4 (each within the scatter of the next).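

In this assay, the place on a saturated chain carbon bound to an amide-type nitrogen accepts a much larger change than the earlier pair had covered: phenyl in place of ethyl gives a 1.0-fold higher number from compound 2 to compound 4 (0.00 log units; within the scatter), and phenyl in place of hydrogen gives a 1.1-fold higher number from compound 1 to compound 4 (0.03 log units; within the scatter). Hydrogen, ethyl and phenyl at this place therefore read alike across compound 1, compound 2 and compound 4, and a six-membered aromatic ring there still leaves a reported number, so the "not active" entry for compound 3, altered at the same place, stands alone among the four compounds. No measurement shown explains why these three read alike or why compound 3 has no number.

On these data alone, it remains open whether any group at this place can produce a step beyond the scatter, since hydrogen, ethyl and phenyl have not done so. A carboxylic acid or an amine carried on this chain, a longer chain, or a substituted phenyl ring such as a methoxyphenyl could answer that, and could also show whether the result for compound 3 is an isolated case.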